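A few compounds are considered here, and "the series" means these few. Any claim that something is new, unique, unknown or untested is made for them only; others in the source may bear on it.

Compound 1 `CC(C)CCn1nc(CC(C)(C)C)c(O)c(C2=NS(=O)(=O)c3cc(NS(C)(=O)=O)ccc3N2)c1=O`: 0.29 10^-6 cm/s
Compound 2 `CC(C)(C)CCn1nc(CC(C)(C)C)c(O)c(C2=NS(=O)(=O)c3cc(NS(C)(=O)=O)ccc3N2)c1=O`: 0.15 10^-6 cm/s
Compound 3 `CN(c1ccc2c(c1)S(=O)(=O)N=C(c1c(O)c(-c3cccs3)nn(CCC(C)(C)C)c1=O)N2)S(C)(=O)=O`: 0.01 10^-6 cm/s

In an ADME assay on Caco-2 cells (Homo sapiens) for permeability, in the apical to basolateral direction, tested at 10 uM (a higher number here means that the compound crosses the layer faster, a lower number that the compound crosses the layer more slowly), compound 3 sits lowest of the three measured compounds, and its gap to compound 2 and compound 1 lies beyond the scatter. How the core of compound 3 differs from the core of compound 2 is not broken down here. Between compound 2 and compound 1 the change is hydrogen in place of methyl on a saturated chain carbon bound to three saturated chain carbons, and it gives a 1.9-fold higher number from compound 2 to compound 1 (0.29 log units; within the scatter).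

Compound 4 `CC(C)CCn1nc(-c2cccs2)c(O)c(C2=NS(=O)(=O)c3cc(N(C)S(C)(=O)=O)ccc3N2)c1=O` has not yet been measured. Going by the values given here, it differs from compound 3 by hydrogen in place of methyl on a saturated chain carbon bound to three saturated chain carbons, the same change as the one from compound 2 to compound 1, at the same kind of place. Since that earlier step gave a 1.9-fold higher number from compound 2 to compound 1 (0.29 log units; within the scatter), compound 4 is expected to move by about a 1.5-fold higher number from compound 3 to compound 4 (0.18 log units; within the scatter) from compound 3. The expectation rests only on that one pair, so it is held loosely, and the estimate for compound 4 is 0.015 10^-6 cm/s, with a range from 0.005 10^-6 cm/s to 0.04 10^-6 cm/s.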

Compound 4, apparent permeability in the Caco-2 assay: 0.2 10^-6 cm/s
Compound 4: the middle estimate sits 13-fold (1.12 log units) below what was measured, outside the stated range (above it).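

In the Caco-2 assay, going from 3,3-dimethylbutyl to isopentyl gives a 20-fold higher number from compound 3 to compound 4 (1.30 log units; beyond the scatter), and set beside the earlier pair, the step does not keep its size from one core to the other: the same change on two cores in the Caco-2 assay, a 1.9-fold higher number (0.29 log units; within the scatter) from compound 2 to compound 1 and a 20-fold higher number (1.30 log units; beyond the scatter) from compound 3 to compound 4, 10-fold (1.01 log units) apart, beyond the scatter of two such steps. This shows that, in these two pairs, the size of the step cannot be carried from one core to the other, but it does not show which difference between the cores goes with the larger step, or what the step would be on any further core. In a physicochemical assay for solubility, at pH 7.4 (a lower number here means a less soluble compound, a higher number a more soluble compound), compound 3 gives > 100000 nM as a limit of the assay and not a number. In the physicochemical assay compound 4 gives > 100000 nM as a limit of the assay and not a number. With compound 3 and compound 4 both at a limit rather than at a number, the step between them cannot be read: the limit of > 100000 nM in the physicochemical assay, at which 2 of the 2 values shown sit.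

The compounds shown leave open how this change would read on a core differing from the core of compound 4 in only one place. They also leave open how a longer chain, or a chain ending in a carboxylic acid, would read in the Caco-2 assay on either core.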